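A few compounds are considered here, and "the series" means these few. Any claim that something is new, unique, unknown or untested is made for them only; others in the source may bear on it.

In a functional assay on the whole organism with Rattus norvegicus as the target (a lower number here means that less compound is needed, a higher number that more compound is needed for the effect), two compounds have been measured so far:

Compound 1 `COc1ccccc1N1CCN(Cc2ccc(-c3ccccc3)[nH]2)CC1` gives 1.9 mg/kg as a number
Compound 2 `COc1ccccc1-c1ccc(CN2CCN(c3ccccc3OC)CC2)[nH]1` gives > 100 mg/kg as a limit

For compound 2 there is only the limit of > 100 mg/kg in this assay, at which 1 of the 2 values shown sits, and no number. Compound 3 `CCS(=O)(=O)c1ccc(OC)c(-c2ccc(CN3CCN(c4ccccc4OC)CC3)[nH]2)c1` differs from compound 2 by one change: ethylsulfonyl in place of hydrogen on an aromatic carbon, para to a methoxy group. For the measured compounds named here, the only measured step is an at least 52-fold higher number from compound 1 to compound 2 (1.72 log units; beyond the scatter), which is large and beyond the scatter. Going by the values given here, it concerns methoxy in place of hydrogen, not ethylsulfonyl, so it shows only that one added group can matter greatly here. Among the compounds with values here, no measured step involves ethylsulfonyl. With that single step as the guide, compound 3 is expected to stay near the limit, possibly with a small move to a lower number. The estimated change is an at least 1.4-fold lower number from compound 2 to compound 3 (0.15 log units; that floor lies within the scatter) and it remains uncertain. Compound 3 is estimated at 70 mg/kg within an expected range of 15 mg/kg to 300 mg/kg in this assay (an expectation only).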

Compound 3, dose for half-maximal effect: > 20 mg/kg
Compound 3 ended at the assay's limit; the forecaster's own chance of this, stated with the estimate: 55%; the middle value lies beyond the limit too.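

In this assay compound 2 gives only a limit (> 100 mg/kg), not a number. For the compounds shown here, compound 3 also gives only a limit (> 20 mg/kg), so no step between compound 2 and compound 3 can be read. The compounds shown leave open both the direction and the size of any effect of ethylsulfonyl in place of hydrogen.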